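The source may hold more compounds than are shown below. What is called first, only, known or untested is meant among the compounds shown, and "the series" means these compounds.

Of the compounds shown here, three of a shared core have been measured in a functional assay on cells (T-cell, Homo sapiens) for inhibition; a higher number here means a weaker inhibitor, a lower number a stronger inhibitor. Compound 1, whose structure is `COc1ccc(-c2cnc3nc(N)nc(N4CCN(C(=O)COc5ccccc5)CC4)c3n2)cc1OC`, gives 4 nM. Its number is the lowest of the three. Compound 2, `COc1ccc(-c2cnc3nc(N)nc(NCc4ccccc4)c3n2)cc1OC`, gives 13000 nM in this assay, and compound 3, `CCOc1nc(N)nc2ncc(-c3ccc(CC)cc3)nc12`, gives 8200 nM. Both of these numbers lie far above that of compound 1, well beyond the usual scatter of repeated runs, so compound 1 is by a clear margin the strongest inhibitor among the three measured here.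

The next compound to be measured is compound 4, with the structure `COc1ccc(-c2cnc3nc(N)nc(N4CCN(C(=O)COc5ccc(Cl)cc5)CC4)c3n2)cc1OC`. It is made from compound 1 by a single small change, counted as chloro in place of hydrogen on an aromatic carbon.

Among the measured compounds shown here, no two measured compounds differ in only one place, so there is no measured step of comparable size to lean on. The change adds one chlorine on the outer phenoxy ring and leaves the rest of compound 1 untouched. Given that compound 1 already gives 4 nM, the step from compound 1 to compound 4 is expected to be small, no change at the digits printed from compound 1 to compound 4 (within the scatter), and not clearly beyond the scatter in either direction. Compound 4 is therefore estimated at 4 nM in this assay, with a range from 1.3 nM to 12 nM.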

Compound 4, half-maximal inhibitory concentration: 0.5 nM
Compound 4: middle estimate off by 8.0-fold (0.90 log units), on the high side, and the stated range ends above it.
By their numbers in this assay, from the lowest: compound 4; then compound 1; then compounds 3 and 2 (each within the scatter of the next).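

In this assay, among the compounds shown here, chloro in place of hydrogen on the phenoxy ring, para to a large group, gives an 8.0-fold lower number from compound 1 to compound 4 (0.90 log units; beyond the scatter), and this is the first step in the set that changes only one place. For the compounds shown here, it shows that this carbon of the phenoxy ring is not a neutral spot: one added heavy atom moves the number by more than the scatter, even though compound 1 was already the lowest of the earlier compounds. The earlier compounds could not show this, since they differ from one another in several places at once, and nothing measured here explains why the chlorine has this effect.

As far as these compounds go, it remains open whether fluoro, bromo, methyl, methoxy or an amine on this same carbon would move the number as chloro does, and whether chloro on another carbon of the phenoxy ring would do the same. This single pair also cannot tell whether the step would carry over to a compound with a different group in place of the phenoxyacetyl piperazine part, such as a longer chain between the carbonyl and the ring.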